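From chloro to bromo in compound 3

A few compounds are considered here, and "the series" means these few. Any claim that something is new, unique, unknown or untested is made for them only; others in the source may bear on it.

Compound 1 `N#Cc1ccc(S(=O)(=O)Nc2ccc(Cl)c3c(Cl)c[nH]c23)cc1` gives 0.12 ug/mL
Compound 2 `Nc1ccc(S(=O)(=O)Nc2ccc(Cl)c3c(Cl)c[nH]c23)cc1` gives 0.1 ug/mL

Within the data shown here, in a functional assay on MC-38 cells (Mus musculus) for antiproliferative activity, read by colorimetric assay and MTT assay (a higher number here means a weaker inhibitor, a lower number a stronger inhibitor), compound 2 at 0.1 ug/mL cannot be told apart from compound 1, the only other compound measured. Compound 3 `Nc1ccc(S(=O)(=O)Nc2ccc(Br)c3c(Cl)c[nH]c23)cc1` has not yet been measured. Its change from compound 2 is bromo in place of chloro on an aromatic carbon and in words it is bromo in place of chloro on an aromatic carbon, para to a large group. Among the measured compounds shown here, the only measured step, a 1.2-fold lower number from compound 1 to compound 2 (0.08 log units; within the scatter) with amino in place of cyano on an aromatic carbon, concerns a different group and leaves this chloro untouched. For the measured compounds named here, no measured step covers this exchange, so no step beyond the scatter is expected in this assay for it. The estimated change is no change at the digits printed from compound 2 to compound 3 (within the scatter) and nothing larger is expected. For compound 3 the estimated value is 0.1 ug/mL with an expected range of 0.05 ug/mL to 0.2 ug/mL around it.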

Compound 3, half-maximal inhibitory concentration: 0.14 ug/mL
Compound 3: middle estimate off by 1.4-fold (0.15 log units), on the low side; measured number inside the range.
By their numbers in this assay, from the lowest: compounds 2, 1 and 3 (each within the scatter of the next).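

In this assay, bromo in place of chloro on an aromatic carbon, para to a large group, gives a 1.4-fold higher number from compound 2 to compound 3 (0.15 log units; within the scatter). The earlier compounds shown here left this chloro untouched, whereas compound 3 shows that this place on the shared core takes a bromo with a difference that cannot be told from the scatter. No further data are available to account for this result.

The compounds shown leave open whether a methyl, a methoxy or an amine at this place would move the number beyond the scatter in this assay. They also leave open whether exchanging the remaining chloro of the shared core for a bromo or a nitrile would do so.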